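Series notes: hydroxy to hydrogen on the aminoethyl chain

A few compounds are considered here, and "the series" means these few. Any claim that something is new, unique, unknown or untested is made for them only; others in the source may bear on it.

Measured in a functional assay on EL4 cells (Mus musculus) for inhibition, tested at 100 uM; on this read-out higher numbers stand for more inhibition at the one concentration tested (going by the name of the read-out) and lower numbers for less inhibition:
Compound 1 `[O-][n+]1ccc2c(c1)ncn2[C@H]1C[C@H](O)[C@@H](CO)O1`: < 5%, a limit of the assay.
Compound 2 `OCCNc1[nH]ccc2ncnc1-2`: < 5%, a limit of the assay.
Compound 3 `OC[C@H]1OC(n2cnc3c(NCc4ccccc4)nccc32)[C@H](O)[C@@H]1O`: 5%.

Compound 2 stands at the floor of this assay with no number of its own, the position described by the limit of < 5% in this assay, at which 2 of the 3 values shown sit. Compound 3 sits within the usual scatter of that floor; the three measured compounds show no separation from one another. Compound 4 `CCNc1[nH]ccc2ncnc1-2` differs from compound 2 by hydrogen in place of hydroxy on a saturated chain carbon, two bonds along the chain from a nitrogen on an aromatic ring. Going by the values given here, no step between measured compounds is available to gauge this change. The expected step that the limit leaves unreadable from compound 2 to compound 4 is none beyond the scatter. Compound 4 is estimated at 3% in this assay, with a range from 0% to 12%, and is most likely to be reported again only as a limit.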

Compound 4, a percentage reported as inhibition, at one concentration (the size of the read-out at that concentration, not a potency): < 5%
Compound 4: only a limit was reported; the forecaster's own chance of this, stated with the estimate: 70%; the middle value is on the limit's open side.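

In this assay compound 2 and compound 4 are both reported only as limits, so no step between them can be read: the limit of < 5% in this assay, at which 3 of the 4 values shown sit.

The compounds shown leave open whether hydrogen in place of hydroxy on this chain changes inhibition at all.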